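Notes on the side-chain aryl change from compound 3 to compound 4

A few compounds are considered here, and "the series" means these few. Any claim that something is new, unique, unknown or untested is made for them only; others in the source may bear on it.

The shared core is seen in compound 1 `Cc1cc(C(=O)O)ccc1CN1CCC[C@H](O[C@H](CO)c2cc(Cl)nc(Cl)c2)[C@@H]1c1ccccc1`. In an assay on isolated protein for activation of cGMP-dependent protein kinase 1 (Homo sapiens), read by ADP-Glo, with stated times of 30 min and 2 h (on this read-out lower numbers stand for an effect already at smaller amounts and higher numbers for an effect only at larger amounts of compound), compound 1 gives only a limit, > 200000 nM. Compound 2 `Cc1cc(C(=O)O)ccc1CN1CCC[C@H](O[C@H](CO)c2cc(F)cc(F)c2)[C@@H]1c1ccccc1` in this assay likewise gives only a limit, > 200000 nM. The step that the two limits leave unreadable from compound 1 to compound 2 is thus unreadable. Compound 3 `Cc1cc(C(=O)O)ccc1CN1CCC[C@H](O[C@H](CO)c2cccc(C(F)(F)F)c2)[C@@H]1c1ccccc1` has no result in this assay, recorded as "nd" (no result reported), so it stands nowhere on the numbers shown. Compound 4 `Cc1cc(C(=O)O)ccc1CN1CCC[C@H](O[C@H](CO)c2cccc(Cl)c2)[C@@H]1c1ccccc1` differs from compound 3 by chloro in place of trifluoromethyl on an aromatic carbon. Within the data shown here, no measured step bears on this change: the one step between measured compounds is unreadable, and the only evidence is the limit of > 200000 nM in this assay, at which 2 of the 3 values shown sit. No direction can be read for this assay. Compound 4 is expected to sit at the limit as well, with an estimate of 200000 nM and a range from 50000 nM to 500000 nM.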

Compound 4, half-maximal effective concentration: 93000 nM
Estimate against measurement, compound 4: 2.2-fold (0.33 log units) above, within the range that was stated.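

The aryl group on the side chain can move the read-out in this assay: 3-chlorophenyl gives an at least 2.1-fold lower number from compound 2 to compound 4 (0.33 log units; beyond the scatter) and an at least 2.1-fold lower number from compound 1 to compound 4 (0.33 log units; beyond the scatter). Both steps are bounds only, and the step between the two limits cannot be read. Limits still mark much of the series: the limit of > 200000 nM in this assay, at which 2 of the 4 values shown sit.

With no result for compound 3, the change from trifluoromethyl to chloro has no readable size. As far as these compounds go, whether a bromo or a nitrile on the same aromatic carbon lowers the number further stays open.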